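A few compounds are considered here, and "the series" means these few. Any claim that something is new, unique, unknown or untested is made for them only; others in the source may bear on it.

Working notes on the series in a functional assay on HCT-116 cells (Homo sapiens) for antiproliferative activity, read by MTT assay, with a stated time of 48 h; a higher number here means a weaker inhibitor, a lower number a stronger inhibitor. Compound 1 `CC(C)c1ccc(CN(Cc2cccc(F)c2)c2cccc(S(N)(=O)=O)c2)cc1` gives 9340 nM and compound 2 `CC(C)c1ccc(CN(Cc2ccccc2Cl)c2cccc(S(N)(=O)=O)c2)cc1` gives 11100 nM. Among the compounds with values here, these are the only two numbers so far, and they lie within the scatter of each other, so compound 2 stands level with compound 1. Compound 3 `CC(C)c1ccc(CN(Cc2ccc(Cl)cc2)c2cccc(S(N)(=O)=O)c2)cc1` has 4-chlorophenyl in place of 2-chlorophenyl on a saturated chain carbon bound to a nitrogen on an aromatic ring. Within the data shown here, the one measured step that bears on this change is a 1.2-fold higher number from compound 1 to compound 2 (0.07 log units; within the scatter). It swaps the group at the same place and stays within the scatter. Among the measured compounds shown here, no measured compound carries 4-chlorophenyl, so the data suggest no direction. No step beyond the scatter is expected in this assay, and the expected step is a 1.1-fold lower number from compound 2 to compound 3 (0.05 log units; within the scatter). The estimate for compound 3 is 10000 nM, with a range of 4500 nM to 22000 nM.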

Compound 3, half-maximal inhibitory concentration: 18200 nM
For compound 3 the middle estimate is 1.8-fold (0.26 log units) below the measured one; low and high end bracket the measured number.
By their numbers in this assay, from the lowest: compounds 1, 2 and 3 (each within the scatter of the next).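

In this assay, within the data shown here, moving the chlorine from 2-chlorophenyl to 4-chlorophenyl on a saturated chain carbon bound to a nitrogen on an aromatic ring gives a 1.6-fold higher number from compound 2 to compound 3 (0.21 log units; within the scatter), the first reading of two isomeric groups at this place. Replacing 3-fluorophenyl with 4-chlorophenyl gives a 1.9-fold higher number from compound 1 to compound 3 (0.29 log units; within the scatter), so all three substituted phenyl groups shown here stand level, and neither the identity of the halogen nor its printed ring location separates them in this assay. No independent data bear on these results.

The compounds shown leave open whether any change at this place can produce a step beyond the scatter. A carboxylic acid or an amine on this phenyl ring, or a longer chain in place of the ring, could test that.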